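The source may report more compounds than this note shows. Statements on the series, on what has been measured and on what is new or still open speak of the compounds shown alone.

Of the compounds shown here, three sharing one core have been measured in a functional assay on LOX IMVI cells (Homo sapiens) for inhibition, read by sulforhodamine B assay, with a stated time of 48 h; on this read-out higher numbers stand for weaker inhibition of growth and lower numbers for stronger inhibition of growth. Compound 1 `Nc1cc(N)c2nc(-c3ccccc3)c(NCc3ccc(Cl)c(Cl)c3)nc2c1` gives 2140 nM. Compound 2 `COc1ccc(CNc2nc3cc(N)cc(N)c3nc2-c2ccccc2)cc1OC` gives 3090 nM. Compound 3 `Nc1cc(N)c2nc(-c3ccccc3)c(NCc3ccc(F)cc3)nc2c1` gives 1510 nM, the lowest of the three numbers, though its step from compound 1 is within the scatter a 1.4-fold lower number from compound 1 to compound 3 (0.15 log units; within the scatter) and only a 2.0-fold lower number from compound 2 to compound 3 (0.31 log units; beyond the scatter) reaches beyond it.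

The next compound, compound 4 `COc1ccc(CNc2nc3cc(N)cc(N)c3nc2-c2ccccc2)cc1`, differs from compound 3 in one place: methoxy in place of fluoro on an aromatic carbon. Within the data shown here, two measured steps bear on this change. The step of a 2.0-fold lower number from compound 2 to compound 3 (0.31 log units; beyond the scatter) is the modest one just mentioned, and a 1.4-fold higher number from compound 1 to compound 2 (0.16 log units; within the scatter) shows what the dimethoxy group does against the dichloro pattern. Both involve a methoxy-bearing group arriving at or leaving this same position, and the methoxy-bearing compound 2 carries the highest number of the three. A single methoxy in place of fluoro is therefore expected to move the number upward, most likely by a step near the edge of the scatter, a 1.5-fold higher number from compound 3 to compound 4 (0.16 log units; within the scatter). Compound 4 is expected to give 2200 nM in this assay, within a range from 1000 nM to 4500 nM.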

Compound 4, concentration for 50% growth inhibition: 13500 nM
Compound 4: the middle estimate sits 6.1-fold (0.79 log units) below what was measured; the whole stated range lies below it.
By their numbers in this assay, from the lowest: compounds 3, 1 and 2 (each within the scatter of the next, the first and the last beyond it); then compound 4.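

In this assay a single methoxy in place of fluoro at this position costs far more than compound 2 suggested, with an 8.9-fold higher number from compound 3 to compound 4 (0.95 log units; beyond the scatter) making compound 4 the weakest of the four. The second methoxy of compound 2 matters greatly, as its removal gives a 4.4-fold higher number from compound 2 to compound 4 (0.64 log units; beyond the scatter) and so the effect of a methoxy here depends on what else the ring carries. The single methoxy also falls well behind the dichloro pattern, with a 6.3-fold higher number from compound 1 to compound 4 (0.80 log units; beyond the scatter) on that comparison, and no measurement at hand explains these steps.

On these data alone, it remains open whether a hydroxyl, an amine or a methyl at this position would give a number nearer that of compound 3 or that of compound 4. The compounds shown also leave open whether this large step is specific to methoxy or would recur with an ethoxy group.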